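The compounds below may be only part of what the source reports. "The series", "measured", "known", "first", "only" and "open" are said of these compounds alone.

Measured so far:
Compound 1, `Cc1nc(Nc2ccccc2)c2cc[nH]c2n1`, in a functional assay on the whole organism for inhibition, with Nicotiana tabacum as the target (a higher number here means a weaker inhibitor, a lower number a stronger inhibitor), compound 1 gives 550000000 nM.
Compound 2, `Cc1nc(Nc2ccc(N)cc2)c2cc[nH]c2n1`, in this assay compound 2 gives 195000000 nM.

Compound 2 stands lowest of the two numbers; its nearest neighbour is compound 1, reached by a 2.8-fold lower number from compound 1 to compound 2 (0.45 log units; beyond the scatter). The unmeasured compound 3 is `Cc1nc(Nc2ccc(C(F)(F)F)cc2)c2cc[nH]c2n1`, and it differs from compound 2 by trifluoromethyl in place of amino on an aromatic carbon. Going by the values given here, the only step that bears on this change is the one from compound 1 to compound 2, a modest one, in which an amino group took the place of hydrogen on that same aromatic carbon. Compound 3 removes that amino group again, so the gain seen in that step is expected to be given back, and what a trifluoromethyl group does in its place is not known from these two compounds. The step from compound 2 to compound 3 is therefore expected to be an increase, about a 2.6-fold higher number from compound 2 to compound 3 (0.41 log units; beyond the scatter). Compound 3 is estimated at 500000000 nM, with a range from 150000000 nM to 1500000000 nM.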

Compound 3, half-maximal inhibitory concentration: 70800000 nM
The estimate for compound 3 lay 7.1-fold (0.85 log units) above the measured number; the measured number lies below the stated range.
By their numbers in this assay, from the lowest: compound 3; then compound 2; then compound 1.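

In this assay, the trifluoromethyl group on this aromatic carbon, para to a large group, gives a lower number than amino, with a 2.8-fold lower number from compound 2 to compound 3 (0.44 log units; beyond the scatter), and a still lower number against plain hydrogen, with a 7.8-fold lower number from compound 1 to compound 3 (0.89 log units; beyond the scatter). The earlier compounds shown here showed a gain only with amino, whereas both groups now give a lower number than hydrogen, and trifluoromethyl does so with 0 hydrogen-bond donors and 0 hydrogen-bond acceptors, so in these compounds neither a donor nor an acceptor at this place is needed for a lower number. No measurement here explains why trifluoromethyl outdoes amino.

The compounds shown leave open how other groups at this place, such as methyl, chlorine, a nitrile or a carboxylic acid, would compare. They also leave open whether the order of hydrogen, amino and trifluoromethyl would hold elsewhere on the same ring.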